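The compounds below may be only part of what the source reports. "The series", "measured", "known", "first", "only" and "open" are said of these compounds alone.

Measured compounds:
compound 1, `[N-]=[N+]=Nc1ccc(CCCNC2CCCC2CCCCCCC(=O)O)cc1` — 20 uM; 20 uM (2 entries)
compound 2, `O=C(O)CCCCCCC1CCCC1NCCCOc1ccccc1` — 20 uM

In a functional assay for agonist activity at thromboxane A2 receptor (Homo sapiens) (on this read-out higher numbers stand for an effect only at larger amounts of compound and lower numbers for an effect already at smaller amounts), compound 1 gives 20 uM; 20 uM (2 entries) on two occasions. In this assay, among the compounds with values here, compound 2 gives 20 uM; this is the sole number for compound 2, a further entry yields no single number. Compound 3, `Nc1ccc(CCCNC2CCCC2CCCCCCC(=O)O)cc1`, is still to be measured in this assay. The change is 4-aminophenyl in place of phenoxy on a saturated chain carbon, three bonds along the chain from an amine nitrogen. Within the data shown here, no step between measured compounds is known, so the size of this step is open; the expected step is no change at the digits printed from compound 2 to compound 3 (within the scatter), with no direction beyond the scatter. Compound 3 is therefore estimated at 20 uM, with a range from 7 uM to 60 uM.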

Compound 3, concentration for half-maximal effect: 20 uM
For compound 3 middle estimate and measured number coincide at the digits printed; low and high end bracket the measured number.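

In this assay, within the data shown here, 4-aminophenyl in place of phenoxy on a saturated chain carbon, three bonds along the chain from an amine nitrogen, gives no change at the digits printed from compound 2 to compound 3 (within the scatter), the first step that can be read at this position. The exchange brings in a hydrogen-bond donor without moving the number beyond the scatter. Nothing at hand explains this result. On these data alone, whether 4-hydroxyphenyl or a longer chain at this place would shift the value stays open. So does the contribution of the carboxylic acid.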